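Bromo to Chloro on a Fused Five-Membered Ring

The source may hold more compounds than are shown below. What is called first, only, known or untested is meant among the compounds shown, and "the series" means these compounds.

Compound 3 `Nc1ncnc2c1c(Br)cn2COC(CO)CO` gives the lowest number of the three measured in a functional assay on L1210 cells (Mus musculus) for inhibition (on this read-out higher numbers stand for weaker inhibition and lower numbers for stronger inhibition), at 710 nM. Within the data shown here, compound 2 `Nc1ncnc2c1c(I)cn2COC(CO)CO` comes nearest, giving 2800 nM in this assay, and the step of a 3.9-fold lower number from compound 2 to compound 3 (0.60 log units; beyond the scatter) is the only measured exchange of one halogen for another. Compound 1 `OC[C@H]1O[C@@H](n2cc(Br)c3c(NO)ncnc32)[C@H](O)[C@@H]1O` stands furthest away, giving 25000 nM in this assay. Compound 4 `Nc1ncnc2c1c(Cl)cn2COC(CO)CO` has not yet been measured; it differs from compound 3 by chloro in place of bromo on an aromatic carbon. Among the measured compounds shown here, the step from compound 2 to compound 3 is the one measurement that bears on this change, and it was modest though beyond the scatter. Nothing measured shows whether a second exchange of halogen would continue in the same direction or fall flat. The author therefore expects a small step toward a lower number, or none beyond the scatter, and estimates it as a 1.4-fold lower number from compound 3 to compound 4 (0.15 log units; within the scatter). Compound 4 is estimated at 500 nM in this assay, with a range from 150 nM to 2000 nM.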

Compound 4, half-maximal inhibitory concentration: 2300 nM
Beside the measured number, compound 4's estimate is 4.6-fold (0.66 log units) below it, and the stated range ends below it.
By their numbers in this assay, from the lowest: compound 3; then compounds 4 and 2 (each within the scatter of the next); then compound 1.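

The step of a 3.2-fold higher number from compound 3 to compound 4 (0.51 log units; beyond the scatter) in this assay shows that replacing bromo on this aromatic carbon of the five-membered ring can cost as much as the exchange from bromo to iodo, so the numbers do not move in one direction along chloro, bromo and iodo. The step of a 1.2-fold lower number from compound 2 to compound 4 (0.09 log units; within the scatter) places chloro and iodo level with each other, and among these three halogens only bromo stands apart, with the lower number. Nothing available accounts for this difference between the halogens.

Going by these compounds, whether fluoro, methyl or ethynyl at this carbon would stay level with chloro and iodo or reach the number of bromo remains open. Also open, on these data alone, is whether bromo would keep its place with a different group on the ring nitrogen.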